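The compounds below may be only part of what the source reports. "The series", "measured", "known", "first", "only" and "open" are said of these compounds alone.

Measured in a functional assay on CEM-SS cells (Homo sapiens) for cytotoxicity; on this read-out lower numbers stand for stronger inhibition and higher numbers for weaker inhibition:
- compound 1 `Nc1nc2cc(Cl)c(Cl)cc2n1Cc1ccc(Cl)cc1`: 32000 nM
- compound 2 `Nc1nc2cc(Cl)c(Cl)cc2n1Cc1ccc(Cl)c(Cl)c1`: 30000 nM
- compound 3 `Nc1nc2cc(Cl)c(Cl)cc2n1Cc1cccc(Cl)c1`: 37000 nM

The three values lie within the scatter of each other, so compound 3 stands level with compound 1 and compound 2 on these numbers. The next compound, compound 4 `Cc1cccc(Cn2c(N)nc3cc(Cl)c(Cl)cc32)c1`, has methyl in place of chloro on an aromatic carbon, meta to a large group: methyl in place of chloro on an aromatic carbon.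

Going by the values given here, two measured steps bear on this change, and both exchange chloro and hydrogen on an aromatic carbon. They are a 1.1-fold lower number from compound 1 to compound 2 (0.03 log units; within the scatter) and a 1.2-fold higher number from compound 2 to compound 3 (0.09 log units; within the scatter), and both stay within the scatter. Among the compounds with values here, no measured compound carries methyl, so the exchange itself is untested and the comparison is only indirect. Given the size of these two steps, no shift beyond the scatter is expected in this assay. The estimated step is a 1.1-fold lower number from compound 3 to compound 4 (0.02 log units; within the scatter), which is expected to remain within the scatter. For compound 4 the estimated value is 35000 nM, with an expected range of 18000 nM to 65000 nM.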

Compound 4, half-maximal inhibitory concentration: 48000 nM
The estimate for compound 4 lay 1.4-fold (0.14 log units) below the measured number, and the stated range covers the measured number.
By their numbers in this assay, from the lowest: compounds 2, 1, 3 and 4 (each within the scatter of the next).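

In this assay, methyl in place of chloro on an aromatic carbon, meta to a large group, gives a 1.3-fold higher number from compound 3 to compound 4 (0.11 log units; within the scatter), and this stays within the scatter. Going by these compounds alone, the earlier steps exchanged only chloro and hydrogen, so this is the first reading of a group other than these two on this ring, and it does not separate methyl from chloro on this read-out. No measurement shown offers an explanation for how close the numbers lie.

All four compounds carry only chloro, methyl or hydrogen on this ring, which leaves open whether an amine, a carboxylic acid or a longer chain at this place would move the number beyond the scatter. The compounds shown also leave open whether any change to the shared core would do so.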